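The source may hold more compounds than are shown below. What is called first, only, known or untested is meant among the compounds shown, and "the series" means these compounds.

Measured compounds in a functional assay on cells (Cancer cell lines, Homo sapiens) for cytotoxicity, read by sulforhodamine B assay, with a stated time of 48 h; a lower number here means a stronger inhibitor of growth, a higher number a weaker inhibitor of growth:
compound 1 `O=C1N=C(N2N=C(c3ccccc3)CC2c2ccccc2O)S/C1=C1/C(=O)Nc2ccccc21`, 2050 nM
compound 2 `O=C1N=C(N2N=C(c3ccccc3)CC2c2ccccc2O)S/C1=C1/C(=O)Nc2ccc(Br)cc21`, 290 nM
compound 3 `Cc1ccc2c(c1)/C(=C1\SC(N3N=C(c4ccccc4)CC3c3ccc(Cl)cc3)=NC1=O)C(=O)N2`, 310 nM

Going by the values given here, compound 2 gives the lowest of the three numbers in this assay; compound 3 sits within the scatter of it, while compound 1 lies well behind, the only measured single-place step being a 7.1-fold lower number from compound 1 to compound 2 (0.85 log units; beyond the scatter), a change on the other aromatic ring.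

Compound 4 `CN(C)c1ccc(C2CC(c3ccccc3)=NN2C2=NC(=O)/C(=C3\C(=O)Nc4ccc(Br)cc43)S2)cc1` differs from compound 2 by 4-(dimethylamino)phenyl in place of 2-hydroxyphenyl on a saturated ring carbon. Among the compounds with values here, no measured step touches this position, so nothing bears directly on it; compound 3 carries a different group there and its value against compound 2 shows nothing beyond the scatter, but the pair differs in two places. The expectation for compound 4 is therefore no step beyond the scatter, with wide uncertainty, a 1.2-fold higher number from compound 2 to compound 4 (0.08 log units; within the scatter). Estimated value for compound 4: 350 nM, range 120 nM to 1100 nM.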

Compound 4, concentration for 50% growth inhibition: 270 nM
For compound 4 the middle estimate is 1.3-fold (0.11 log units) above the measured one; the measured number falls inside the stated range.
By their numbers in this assay, from the lowest: compounds 4, 2 and 3 (each within the scatter of the next); then compound 1.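

On the saturated ring carbon next to the ring nitrogen, 4-(dimethylamino)phenyl in place of 2-hydroxyphenyl gives in this assay a 1.1-fold lower number from compound 2 to compound 4 (0.03 log units; within the scatter). With the bromo group in place, this position therefore tolerates this exchange, including the loss of the hydrogen-bond donor of 2-hydroxyphenyl, without a step beyond the scatter. No measurement at hand accounts for this result.

Still open, as far as these compounds go, is whether a carboxylic acid or a primary amine on this phenyl ring would leave the number unchanged. Also open, from the compounds shown here alone, is whether the same exchange would behave alike without the bromo group.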